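The source may report more compounds than this note shows. Statements on the series, on what has been measured and on what is new or still open speak of the compounds shown alone.

Measured in a toxicity assay on THP-1 cells (Homo sapiens) for inhibition; on this read-out higher numbers stand for lower toxicity in this test and lower numbers for higher toxicity in this test:
- compound 1 `COc1ccc(-c2cnc(NC(=O)c3ccccc3)n2C)cc1`: > 100000 nM (a limit)
- compound 2 `COc1ccc(-c2cnc(NC(=O)C3CCCC3)n2C)cc1`: > 100000 nM (a limit)
- compound 3 `COc1ccc(-c2cnc(NC(=O)c3ccc(C#N)cc3)n2C)cc1`: > 100000 nM (a limit)

Compound 3 gives > 100000 nM, which is a limit of the assay and not a number. It therefore shows no measurable toxicity here, and neither of the other two compounds gives a number.

Compound 4 `COc1ccc(-c2cnc(NC(=O)C3CCOCC3)n2C)cc1` carries oxan-4-yl in place of 4-cyanophenyl on a carbonyl carbon.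

The nearest measured change is a step that the two limits leave unreadable from compound 2 to compound 3. It also swaps 4-cyanophenyl against a non-aromatic ring at this place. Two further changes are a step that the two limits leave unreadable from compound 1 to compound 2 and a step that the two limits leave unreadable from compound 1 to compound 3. None of these has a readable size, yet no change of group has brought a number into view so far.

No step beyond the scatter is expected in this assay because of the limit of > 100000 nM in this assay, at which 3 of the 3 values shown sit. The expected step is a number no higher from compound 3 to compound 4 (the limit leaves the size open). For compound 4 the estimate is 100000 nM, with an expected range from 50000 nM to 200000 nM.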

Compound 4, half-maximal cytotoxic concentration: > 100000 nM
Compound 4 gave a limit, no number; the forecaster's own chance of this, stated with the estimate: 90%; the middle value sits exactly at the limit.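

In this assay compound 4 gives > 100000 nM, which is a limit of the assay and not a number, so its steps from compound 1, compound 2 and compound 3 cannot be read. The compounds shown leave open at what concentration, if any, they become toxic to these cells, because every result stops at the same point: the limit of > 100000 nM in this assay, at which 4 of the 4 values shown sit.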